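The compounds below may be only part of what the source reports. "The series", "measured", "known", "first", "only" and "open" are said of these compounds alone.

Measured compounds:
Compound 1, `Cc1nn(-c2ncnc3nc[nH]c23)c2c1C(OCc1ccccc1C#N)CC(=O)N2`: in a functional assay on HEK293 cells for agonist activity at G-protein coupled receptor 39 (Homo sapiens), read by scintillation proximity assay and inositol phosphate accumulation, with a stated time of 75 min, in the presence of a further agent that is not named here (a higher number here means that more compound is needed for the effect, a lower number that less compound is needed), compound 1 gives 8 nM.
Compound 2, `Cc1noc(C)c1COC1CC(=O)Nc2c1c(C)nn2-c1ncnc2nc[nH]c12`: in this assay compound 2 gives 5 nM.
Compound 3, `Cc1nn(-c2ncnc3nc[nH]c23)c2c1C(OCc1ccc(C#N)cc1)CC(=O)N2`: in this assay compound 3 gives 4 nM.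

Compound 3 has the lowest of the three numbers, but its neighbours sit close: the step of a 1.3-fold lower number from compound 2 to compound 3 (0.10 log units; within the scatter) and the step of a 2.0-fold lower number from compound 1 to compound 3 (0.30 log units; within the scatter) both stay within the scatter, as does the step of a 1.6-fold lower number from compound 1 to compound 2 (0.20 log units; within the scatter). On these numbers the three compounds cannot be told apart.

Compound 4, `Cc1nn(-c2ncnc3nc[nH]c23)c2c1C(C(=O)N(C)c1ccccc1)CC(=O)N2`, differs from compound 3 in one place: methyl(phenyl)carbamoyl in place of (4-cyanobenzyl)oxy on a saturated ring carbon. Going by the values given here, none of the measured steps touches this change. All three of them exchange one aromatic group for another while the oxygen link to the saturated ring carbon stays in place; here that link itself is exchanged for a carbonyl bound to a methylated nitrogen. Among the compounds with values here, the measured steps show only that the aromatic group can vary without a step beyond the scatter, so no direction can be read from them for compound 4.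

Compound 4 is therefore estimated at 20 nM, with a range from 4 nM to 120 nM, which means an expected step of a 5.0-fold higher number from compound 3 to compound 4 (0.70 log units; beyond the scatter), taken with little confidence.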

Compound 4, half-maximal effective concentration: 32 nM
Beside the measured number, compound 4's estimate is 1.6-fold (0.20 log units) below it; measured number inside the range.
By their numbers in this assay, from the lowest: compounds 3, 2 and 1 (each within the scatter of the next); then compound 4.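

In this assay, this position on the saturated ring carbon now shows steps beyond the scatter, which the exchanges of the aromatic group had not produced: methyl(phenyl)carbamoyl in place of the oxygen-linked groups gives an 8.0-fold higher number from compound 3 to compound 4 (0.90 log units; beyond the scatter), a 6.4-fold higher number from compound 2 to compound 4 (0.81 log units; beyond the scatter) and a 4.0-fold higher number from compound 1 to compound 4 (0.60 log units; beyond the scatter). All three oxygen-linked groups, with or without a nitrile, therefore stand on the same side of compound 4, so the tolerance seen among them does not extend to this exchange. The groups of compound 3 and compound 4 match in heavy atoms and each hold one six-membered aromatic ring of carbon only, so these counts do not separate the two compounds.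

Still open, on these data alone, is which part of the exchange goes with the step, since the link and the nitrile change together between compound 3 and compound 4. A 4-cyanophenyl group on the same carbamoyl link, the amide hydrogen in place of the methyl, or a carbamoyl group with a longer chain in place of the methyl would each bear on that question. Nothing available here explains the step.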